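A few compounds are considered here, and "the series" means these few. Any claim that something is new, unique, unknown or untested is made for them only; others in the source may bear on it.

The measured compounds:
compound 1, `CC(=O)c1cc2ccc(OCCCn3cc(CNC(=O)CCCCC4CCSS4)nn3)cc2oc1=O`, 39.8%
compound 2, `CCOC(=O)c1cc2ccc(OCCCn3cc(CNC(=O)CCCCC4CCSS4)nn3)cc2oc1=O`, 42.1%
compound 3, `O=C(CCCCC1CCSS1)NCc1cn(CCCOc2ccc3cc(-c4ccccc4)c(=O)oc3c2)nn1`, 27.2%

In a functional assay on PC-12 cells (Rattus norvegicus) for cytotoxicity, read by MTT assay, with stated times of 3 h and 2 h, tested at 20 uM (on this read-out lower numbers stand for a weaker effect and higher numbers for a stronger effect at the one concentration tested), compound 2 gives the highest of the three numbers, though compound 1 lies within the scatter of it; only compound 3 sits clearly lower. The step to compound 4, `O=C(CCCCC1CCSS1)NCc1cn(CCCOc2ccc3cc(-c4ccc(Cl)c(Cl)c4)c(=O)oc3c2)nn1`, exchanges (3,4-dichlorophenyl in place of ethoxycarbonyl on an aromatic carbon). For the measured compounds named here, two measured steps bear on it: a number 14.9 percentage points lower from compound 2 to compound 3 (beyond the scatter) and, from compound 1, a number 12.6 percentage points lower from compound 1 to compound 3 (beyond the scatter). Both place a phenyl group on the same aromatic carbon and both lowered the read-out by a modest amount; nothing measured shows what the two chlorines add. The expected step is therefore a number 14.1 percentage points lower from compound 2 to compound 4 (beyond the scatter), downward and beyond the scatter. Compound 4 is thus estimated at 28% in this assay, with a range from 14% to 42%.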

Compound 4, a percentage reported as activity, at one concentration (the size of the read-out at that concentration, not a potency): 51.2%
Compound 4: middle estimate off by 23.2 percentage points, on the low side; the measured number lies above the stated range.
By their numbers in this assay, from the lowest: compound 3; then compounds 1, 2 and 4 (each within the scatter of the next, the first and the last beyond it).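

In this assay, the two chlorines change what a phenyl group does at this aromatic carbon, with a number 24 percentage points higher from compound 3 to compound 4 (beyond the scatter), so a phenyl group here does not by itself bring a lower read-out. Against the ethoxycarbonyl group, the 3,4-dichlorophenyl group gives a number 9.1 percentage points higher from compound 2 to compound 4 (within the scatter), while against the acetyl group it gives a number 11.4 percentage points higher from compound 1 to compound 4 (beyond the scatter). No measurement offered here explains this change.

Going by these compounds, whether a single chlorine would be enough, and which of the two positions carries the change, stays open. So does the read-out with an amine or a carboxylic acid on the phenyl ring.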